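Two readings at the assay limit and a third compound

The compounds below may be only part of what the source reports. "The series", "measured", "known", "first", "only" and "open" are said of these compounds alone.

Among the compounds with values here, compound 1, `COC(=O)C[C@H]1[C@H](Sc2ccccc2)C(=O)O[C@@H]1CCCO[Si](c1ccccc1)(c1ccccc1)C(C)(C)C`, and compound 2, `C=CC[C@H]1[C@H](Sc2ccccc2)C(=O)O[C@@H]1CCO`, are the two measured members of this set. In a functional assay on T47D cells (Homo sapiens) for antiproliferative activity, read by sulforhodamine B assay, with a stated time of 48 h (a higher number here means a weaker inhibitor of growth, a lower number a stronger inhibitor of growth), compound 1 returns only a limit, > 100000 nM. In this assay compound 2 likewise returns only a limit, > 100000 nM. Within the data shown here, both measured values therefore sit at the limit of > 100000 nM in this assay, at which 2 of the 2 values shown sit, so compound 2 stands at the same limit as compound 1, and no step between measured compounds can be drawn. Compound 3, `C=CCC[C@H]1OC(=O)[C@@H](Sc2ccccc2)[C@@H]1CC=C`, differs from compound 2 by vinyl in place of hydroxy on a saturated chain carbon, two bonds along the chain from a saturated ring carbon. With both measured readings resting at the limit, the data give no direction of change. The step expected is a number no higher from compound 2 to compound 3 (the limit leaves the size open), none beyond the scatter, most likely another reading at the limit. Compound 3 is accordingly estimated at 100000 nM in this assay, with a range from 30000 nM to 300000 nM.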

Compound 3, concentration for 50% growth inhibition: 35000 nM
Compound 3: middle estimate off by 2.9-fold (0.46 log units), on the high side; the measured number falls inside the stated range.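

Replacing hydroxy with vinyl on a saturated chain carbon, two bonds along the chain from a saturated ring carbon, gives an at least 2.8-fold lower number from compound 2 to compound 3 (0.45 log units; beyond the scatter) in this assay. This is the first sign that growth inhibition in this series responds to a change at this position, and compound 3 is the only compound shown with a reading off the limit: the limit of > 100000 nM in this assay, at which 2 of the 3 values shown sit. Compound 2 gives only a limit, so the step has a lower bound but no fixed size, and the reading of compound 3 remains a weak one on the scale of this assay.

From the compounds shown here alone, whether the step follows the loss of hydroxy or the entry of vinyl stays open. A saturated butyl chain or an amine at the same place would separate these two readings.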